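A Dimethylaminopyridine Swap in Place of a Pyrazole

The source may report more compounds than this note shows. Statements on the series, on what has been measured and on what is new or still open speak of the compounds shown alone.

Compound 1 `O=C(O)Cc1sc(C(c2ccc(F)cc2)c2ccc(F)cc2)nc1-c1ccccc1`: 240 nM
Compound 2 `O=C(O)Cc1sc(C(c2ccc(F)cc2)c2ccc(F)cc2)nc1-c1ccnc(N2CCCC2)c1`: a limit, > 100000 nM
Compound 3 `O=C(O)Cc1sc(C(c2ccc(F)cc2)c2ccc(F)cc2)nc1-c1cn[nH]c1`: 220 nM

In an in vitro functional assay on HEK285-7 cells for antagonist activity at prostaglandin D2 receptor 2 (Homo sapiens), read by BRET and beta-arrestin recruitment (a higher number here means a weaker inhibitor, a lower number a stronger inhibitor), compound 1 gives 240 nM. Compound 2 gives no number but only a limit, > 100000 nM. Compound 3 gives 220 nM; the step of a 1.1-fold lower number from compound 1 to compound 3 (0.04 log units; within the scatter) is within the scatter, so compound 3 and compound 1 stand together at the low end of the numbers shown. Compound 4 `CN(C)c1cc(-c2nc(C(c3ccc(F)cc3)c3ccc(F)cc3)sc2CC(=O)O)ccn1` has not been measured. 2-(dimethylamino)pyridin-4-yl in place of 1H-pyrazol-4-yl on an aromatic carbon The group entering compound 4 resembles the 2-(pyrrolidin-1-yl)pyridin-4-yl of compound 2, and the steps of an at least 410-fold higher number from compound 1 to compound 2 (2.61 log units; beyond the scatter) and an at least 450-fold lower number from compound 2 to compound 3 (2.65 log units; beyond the scatter) show that a pyridine of this kind, in place of phenyl or of 1H-pyrazol-4-yl, carried the number to the limit (the limit of > 100000 nM in this assay, at which 1 of the 3 values shown sits). A large step upward is therefore expected, a 140-fold higher number from compound 3 to compound 4 (2.13 log units; beyond the scatter), though the dimethylamino group is not the pyrrolidine, so whether the limit is reached again is uncertain. Compound 4 is estimated at 30000 nM, between 3000 nM and 100000 nM.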

Compound 4, half-maximal inhibitory concentration: > 100000 nM
Compound 4: a limit, no number; the forecaster's own chance of this, stated with the estimate: 50%; at least 3.3-fold (0.52 log units) between middle value and limit.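

Two different amino groups on the pyridine now end in the same place, so the result does not depend on the pyrrolidine ring of compound 2. With dimethylamino in its stead, on the same aromatic carbon next to the ring nitrogen, the change gives an at least 450-fold higher number from compound 3 to compound 4 (2.65 log units; beyond the scatter) and an at least 410-fold higher number from compound 1 to compound 4 (2.61 log units; beyond the scatter). The step from compound 2 to compound 4 cannot be read, and the two amino groups cannot be ranked in this assay, because both compounds sit at a limit: the limit of > 100000 nM in this assay, at which 2 of the 4 values shown sit.

Still open, on these data alone, is whether the pyridine ring or the amino group on it accounts for these large steps. An unsubstituted pyridin-4-yl would help separate the two, and a methoxy group in place of the amine would show whether the amino nitrogen matters.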